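The source may report more compounds than this note shows. Statements on the series, on what has been measured and on what is new or still open speak of the compounds shown alone.

Measured compounds:
compound 1 `Cc1ccnnc1N1CCN(C(=O)Nc2ccc(C(C)(C)C)cc2)[C@H](C)C1` — 8.5 nM
compound 2 `Cc1cc(Cl)nnc1N1CCN(C(=O)Nc2ccc(C(C)(C)C)cc2)[C@H](C)C1` — 10 nM
Not yet measured: compound 3 `Cc1cc(N2CCN(C(=O)Nc3ccc(C(C)(C)C)cc3)[C@H](C)C2)nnc1Cl`

In an assay on HEK293 cells for inhibition of transient receptor potential cation channel subfamily V member 1 (Homo sapiens), read by FLIPR (a higher number here means a weaker inhibitor, a lower number a stronger inhibitor), compound 2 gives 10 nM, the higher of the two numbers, and compound 1 gives 8.5 nM; the step of a 1.2-fold higher number from compound 1 to compound 2 (0.07 log units; within the scatter). Compound 3 differs from compound 2 by 6-chloro-5-methylpyridazin-3-yl in place of 6-chloro-4-methylpyridazin-3-yl on an amine nitrogen in a ring. For the measured compounds named here, no measured step covers such a shift of the methyl group within the chloro-bearing ring; the only step available concerns the chloro substituent, which compounds 2 and 3 share. The expected step is therefore modest, probably upward, and uncertain: a 2.0-fold higher number from compound 2 to compound 3 (0.30 log units; within the scatter). Compound 3 is estimated at 20 nM, in a range from 6 nM to 70 nM.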

Compound 3, half-maximal inhibitory concentration: 8120 nM
Compound 3: middle estimate off by 410-fold (2.61 log units), on the low side; measured number outside the range, above it.
By their numbers in this assay, from the lowest: compounds 1 and 2 (each within the scatter of the next); then compound 3.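

In this assay, 6-chloro-5-methylpyridazin-3-yl in place of 6-chloro-4-methylpyridazin-3-yl gives an 810-fold higher number from compound 2 to compound 3 (2.91 log units; beyond the scatter), with the same atoms joined differently, so the placement of the methyl group matters greatly in this series. Against the unchlorinated 4-methylpyridazin-3-yl group, the change gives a 960-fold higher number from compound 1 to compound 3 (2.98 log units; beyond the scatter), whereas adding chloro alone gave only a 1.2-fold higher number from compound 1 to compound 2 (0.07 log units; within the scatter). Nothing available explains the loss.

Still open, going by these compounds, is whether the loss comes from the methyl group leaving its original place or from its arrival at the new one. Also open, on these data alone, is how an ethyl, methoxy or amine group would fare at either place.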